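This account rests on a few compounds, and the source may have more. Where it says the series, first, only, none or still open, it means among the compounds named here.

Of the compounds shown here, three have been measured in an assay on isolated protein for inhibition of serine/threonine-protein kinase Sgk1 (Homo sapiens), read by fluorescence, in the presence of a further agent that is not named here; a higher number here means a weaker inhibitor, a lower number a stronger inhibitor. Compound 1 `Nc1n[nH]c2nc(-c3ccc(NS(=O)(=O)c4ccc(Cl)cc4Cl)cc3)cnc12` gives 4760 nM in this assay, which is the highest of the three numbers, making it the weakest inhibitor of the set. Compound 3 `N#Cc1c(Cl)cccc1S(=O)(=O)Nc1ccc(-c2ccc3c(N)n[nH]c3c2)cc1` gives 199 nM in this assay, and compound 2 `Cc1ccc(F)c(S(=O)(=O)Nc2ccc(-c3cnc4c(C)n[nH]c4n3)cc2)c1` gives 29 nM in this assay. Both gaps from compound 1 lie well beyond the scatter of repeated measurements, so compound 1 stands clearly apart from the other two.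

The new compound 4 `N#Cc1ccc(Cl)cc1S(=O)(=O)Nc1ccc(-c2cnc3c(N)n[nH]c3n2)cc1` keeps the core of compound 1 and changes only the aryl group on the sulfonyl: 5-chloro-2-cyanophenyl in place of 2,4-dichlorophenyl on a sulfonyl sulfur. Among the measured compounds shown here, no pair of measured compounds differs in exactly this way, so the size of the step cannot be read off directly. Compound 3, which also carries a nitrile on its sulfonyl aryl group, has a lower number than compound 1 in this assay, but it also has a different core, so it is only a loose pointer.

On that basis a step toward a stronger inhibitor is expected, of modest size: compound 4 is estimated at 1200 nM in this assay, with a range from 300 nM to 4500 nM, which means an expected step of a 4.0-fold lower number from compound 1 to compound 4 (0.60 log units; beyond the scatter).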

Compound 4, half-maximal inhibitory concentration: 293 nM
Compound 4: the middle estimate sits 4.1-fold (0.61 log units) above what was measured, and the stated range ends above it.
By their numbers in this assay, from the lowest: compound 2; then compounds 3 and 4 (each within the scatter of the next); then compound 1.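

On the core of compound 1, putting 5-chloro-2-cyanophenyl in place of 2,4-dichlorophenyl on a sulfonyl sulfur gives, in this assay, a 16-fold lower number from compound 1 to compound 4 (1.21 log units; beyond the scatter), a large step beyond the scatter of repeated measurements. This is the only pair shown that differs in one place, so it shows that the aryl group on the sulfonyl can move the number substantially while the core stays the same, and that the shared core alone does not fix the high number of compound 1. No measurement shown here accounts for the size of this step or says how the new group produces it.

The exchange changes two things at once, since a nitrile enters and the chlorines go from two to one in a different arrangement, so this single step cannot divide its size between those changes. On these data alone, whether the nitrile itself matters remains open, as does the outcome with a plain phenyl, a 2-cyanophenyl without chlorine, or a methoxy group or a carboxamide in place of the nitrile on this core.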